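Cytotoxicity notes: pyridin-4-yl in place of 2-cyanophenyl

The source may report more compounds than this note shows. Statements on the series, on what has been measured and on what is new or still open speak of the compounds shown alone.

Values in an ADME assay on HeLa Rh cells (Homo sapiens) for cytotoxicity, read by microscopy; on this read-out higher numbers stand for lower toxicity in this test and lower numbers for higher toxicity in this test:
- compound 1 `COc1cc(CC(O)c2ccc(-c3ccc([N+](=O)[O-])cc3)cc2)c([N+](=O)[O-])cc1OC`: 21000 nM
- compound 2 `COc1cc(CC(O)c2ccc(-c3ccccc3C#N)cc2)c([N+](=O)[O-])cc1OC`: 9300 nM

Among the compounds with values here, of the two numbers so far, compound 2 holds the lower. Compound 3 `COc1cc(CC(O)c2ccc(-c3ccncc3)cc2)c([N+](=O)[O-])cc1OC` carries pyridin-4-yl in place of 2-cyanophenyl on an aromatic carbon. Within the data shown here, one measured step bears on this place: a 2.3-fold lower number from compound 1 to compound 2 (0.35 log units; beyond the scatter). It is modest, and a single step shows no trend. No larger change is expected here, with a slight lean toward a higher number. The expected step is a 1.4-fold higher number from compound 2 to compound 3 (0.15 log units; within the scatter). For compound 3 the estimate is 13000 nM, with an expected range of 5000 nM to 30000 nM.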

Compound 3, half-maximal cytotoxic concentration: > 263000 nM
Compound 3: only a limit was reported; the forecaster's own chance of this, stated with the estimate: 10%; middle value at least 20-fold (1.30 log units) from the limit.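

In this assay, this position proves far more sensitive than the first pair suggested: swapping between the two substituted phenyl groups gave only a 2.3-fold lower number from compound 1 to compound 2 (0.35 log units; beyond the scatter), whereas pyridin-4-yl gives an at least 28-fold higher number from compound 2 to compound 3 (1.45 log units; beyond the scatter) and an at least 12-fold higher number from compound 1 to compound 3 (1.09 log units; beyond the scatter). Both large steps run toward lower toxicity in this test. Compound 3 has only a limit of the assay: the limit of > 263000 nM in this assay, at which 1 of the 3 values shown sits.

The compounds shown do not separate the role of the ring nitrogen from the loss of the nitrile or nitro substituent. Open, from the compounds shown here alone, is where a plain phenyl or a pyridin-3-yl would fall on this read-out relative to pyridin-4-yl.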